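Adding isopropyl to the side chain of compound 3

A few compounds are considered here, and "the series" means these few. Any claim that something is new, unique, unknown or untested is made for them only; others in the source may bear on it.

Within the data shown here, in an ADME assay on microsomes from liver (Homo sapiens) for metabolic stability, with a stated time of 30 min (a higher number here means that more of the compound is left, a lower number that less of the compound is left), compound 1 (`CC(C)[C@@H](CO)n1cc(C(=O)O)c(=O)c2cc(Cc3cccc(Cl)c3F)ncc21`) gives 100% and is the only compound in this small set with a number. For compound 2 (`CC(C)[C@@H](CO)n1cc(C(=O)O)c(=O)c2nc(Cc3cccc(Cl)c3F)ccc21`) the entry reads "not determined" (no result reported) and no figure exists. Compound 3 (`COc1nc2c(cc1Cc1cccc(Cl)c1F)c(=O)c(C(=O)O)cn2[C@@H](C)CO`) has the same gap, with "not determined" (no result reported) as its entry, so it holds no place on the scale.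

Compound 4 (`COc1nc2c(cc1Cc1cccc(Cl)c1F)c(=O)c(C(=O)O)cn2[C@H](CO)CC(C)C`) differs from it in one place: isopropyl in place of hydrogen on a saturated chain carbon, two bonds along the chain from an aromatic nitrogen and the same difference, cut one bond further out, reads methyl to isobutyl.

Without a number for compound 3, no step can be read from the data. Among the measured compounds shown here, the only guide is compound 1 at 100% in the same measurement. A small downward step in this assay is therefore expected, possibly none beyond the scatter. The estimate for compound 4 is 85% in this assay with 60% to 100% as the expected range of the measurement.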

Compound 4, percent of the compound remaining: 92%
Compound 4: middle estimate off by 7 percentage points, on the low side; the range from low to high includes it.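

No step can be read between compound 3 and compound 4 in this assay, where compound 4 gives 92% and compound 3 has no single number. The compounds shown leave open what isopropyl on the side chain does to this read-out. No evidence on hand bears on the result.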